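Chloro for methyl on the acyl group: a repeated change

The source may hold more compounds than are shown below. What is called first, only, known or untested is meant among the compounds shown, and "the series" means these compounds.

Four pyrazoline-type compounds are compared. Compound 1 `CC1=NN(C(=O)CCl)C(c2cc(Br)ccc2O)C1` and compound 2 `CCC(=O)N1N=C(C)CC1c1cc(Br)ccc1O` share one core; compound 3 `CCC(=O)N1N=C(c2cc3ccccc3oc2=O)CC1c1ccccc1` and compound 4 `O=C(CCl)N1N=C(c2cc3ccccc3oc2=O)CC1c1ccccc1` share another. The difference between the two cores is not broken down here.

In a functional assay on MGC-803 cells (Homo sapiens) for cytotoxicity, read by MTT assay, with a stated time of 48 h (on this read-out lower numbers stand for stronger inhibition and higher numbers for weaker inhibition), compound 2 gives 50300 nM, and compound 1 gives 13500 nM. Between them one change is made, (chloro in place of methyl on a saturated chain carbon bound to a carbonyl carbon), and it produced a 3.7-fold lower number from compound 2 to compound 1 (0.57 log units; beyond the scatter).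

Compound 3 gives 5300 nM in this assay, the lowest of the three measured numbers. Compound 4 has not been measured; it differs from compound 3 by chloro in place of methyl on a saturated chain carbon bound to a carbonyl carbon. Among the measured compounds shown here, this is the same change as from compound 2 to compound 1, at the same place, so the earlier step is the only guide.

Compound 4 is therefore expected to show a step of about a 2.9-fold lower number from compound 3 to compound 4 (0.47 log units; beyond the scatter), resting on the step from compound 2 to compound 1 and on compound 3 giving 5300 nM. The estimate for compound 4 is 1800 nM, with a likely range from 600 nM to 5500 nM.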

Compound 4, half-maximal inhibitory concentration: 2020 nM
The estimate for compound 4 lay 1.1-fold (0.05 log units) below the measured number; the range from low to high includes it.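

In this assay, chloro in place of methyl on a saturated chain carbon bound to a carbonyl carbon gives a 2.6-fold lower number from compound 3 to compound 4 (0.42 log units; beyond the scatter) and so lowers the number on the core of compound 3, as it did on the core of compound 1. The two steps point the same way and cannot be told apart in size: the same change on two cores in this assay, a 3.7-fold lower number (0.57 log units; beyond the scatter) from compound 2 to compound 1 and a 2.6-fold lower number (0.42 log units; beyond the scatter) from compound 3 to compound 4, 1.4-fold (0.15 log units) apart, within the scatter of two such steps

This means that the effect of the change carried over between these two cores, so the step seen on one was a fair guide to the step on the other. Two pairs of compounds cannot show that it would carry over to a third core, and they do not explain why the number falls.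

From the compounds shown here alone, whether an amine, a hydroxyl group or a longer chain in place of chloro at this position would lower the number further remains open. Going by these compounds, it is also open whether the same step would appear on a different cell line.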